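Removing a methoxy from the indole ring of a cytotoxic enone

The compounds below may be only part of what the source reports. "The series", "measured", "known", "first", "only" and "open" are said of these compounds alone.

Compound 1 `COc1ccc2[nH]cc(C(=O)/C(C#N)=C/C=C(\Cl)c3ccc(OC)c(OC)c3)c2c1`: in a functional assay on MCF7 cells (Homo sapiens) for cytotoxicity, read by sulforhodamine B assay, with a stated time of 48 h (a higher number here means that more compound is tolerated, a lower number that less compound is tolerated), compound 1 gives > 100000 nM, which is a limit of the assay and not a number.
Compound 2 `COc1ccc2[nH]cc(C(=O)/C(C#N)=C/C=C(\Cl)c3ccc(Br)cc3)c2c1`: in this assay compound 2 gives > 100000 nM, again a limit and not a number.

Compound 1 therefore stands at the upper limit of this assay; no number is known for it, only that it sits at the limit, as described by the limit of > 100000 nM in this assay, at which 2 of the 2 values shown sit. Among the measured compounds shown here, the one measured step, a step that the two limits leave unreadable from compound 1 to compound 2, cannot be read, since both of its ends are limits.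

Compound 3 `COc1ccc(/C(Cl)=C/C=C(\C#N)C(=O)c2c[nH]c3ccccc23)cc1OC` differs from compound 1 by hydrogen in place of methoxy on an aromatic carbon of the shared core. For the measured compounds named here, no measured step touches this position, so nothing shows how the change should act. Compound 1 itself gives only a limit, so the most likely outcome for compound 3 is expected to be a further limit, and the step that the limit leaves unreadable from compound 1 to compound 3 is estimated as none beyond the scatter. For compound 3 the estimate is 150000 nM, within 40000 nM to 600000 nM.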

Compound 3, concentration lethal to 50% of the cells: > 100000 nM
Compound 3 gave a limit, no number; the forecaster's own chance of this, stated with the estimate: 75%; the middle value is on the limit's open side.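

Compound 3, like compound 1, gives only a limit and not a number, so the step between them cannot be read. Whether hydrogen in place of methoxy on an aromatic carbon changes the cytotoxicity at all stays open, as does the size of any difference among compound 1, compound 2 and compound 3: the limit of > 100000 nM in this assay, at which 3 of the 3 values shown sit.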